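Taking the ethyl group off compound 2

The source may report more compounds than this note shows. Statements on the series, on what has been measured and on what is new or still open speak of the compounds shown alone.

Measured in a functional assay on A549 cells (Homo sapiens) for cytotoxicity, read by MTT assay, with a stated time of 72 h; on this read-out lower numbers stand for stronger inhibition and higher numbers for weaker inhibition:
Compound 1 `CNC(=O)c1cc(Oc2ccc(NC(=O)c3cc(-c4ccc(Br)cc4)ncn3)cc2)ccn1` gives > 100000 nM as a limit of the assay
Compound 2 `CCc1ccc(-c2cc(C(=O)Nc3ccc(Oc4ccnc(C(=O)NC)c4)cc3)ncn2)cc1` gives 13300 nM
Compound 3 `CCc1ccc(-c2cc(C(=O)Nc3ccc(Oc4ccnc(C(=O)NC)c4)c(F)c3)ncn2)cc1` gives 3390 nM

Going by the values given here, of the two true numbers, the one for compound 2 is the higher. Compound 4 `CNC(=O)c1cc(Oc2ccc(NC(=O)c3cc(-c4ccccc4)ncn3)cc2)ccn1` carries hydrogen in place of ethyl on an aromatic carbon and awaits testing. The closest evidence comes from that same carbon, where ethyl in place of bromo gave an at least 7.5-fold lower number from compound 1 to compound 2 (0.87 log units; beyond the scatter) in this assay on the way to compound 2. Fluoro in place of hydrogen elsewhere gave a 3.9-fold lower number from compound 2 to compound 3 (0.59 log units; beyond the scatter) and bears less directly. Among the compounds with values here, no measured step removes the group outright, so the direction is uncertain, but a higher number seems likelier. The expected change is a 1.9-fold higher number from compound 2 to compound 4 (0.27 log units; within the scatter) as an estimate. Compound 4 is expected near 25000 nM (7000 nM to 90000 nM).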

Compound 4, half-maximal inhibitory concentration: 27100 nM
For compound 4 the middle estimate is 1.1-fold (0.04 log units) below the measured one; the measured number falls inside the stated range.
By their numbers in this assay, from the lowest: compound 3; then compound 2; then compound 4. At a limit, above all of these: compound 1.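

In this assay, hydrogen now serves as the reference at this carbon, and the 4-ethylphenyl to phenyl change gives a 2.0-fold higher number from compound 2 to compound 4 (0.31 log units; beyond the scatter), so ethyl lowers the number relative to no group at all. Bromo goes the other way, with an at least 3.6-fold lower number from compound 1 to compound 4 (0.56 log units; beyond the scatter), so having a group here does not by itself lower the number. That second step rests on compound 1, whose value is a limit: the limit of > 100000 nM in this assay, at which 1 of the 4 values shown sits.

Going by these compounds, whether an amine or a longer chain such as propyl at this carbon would fall below ethyl stays open. So does whether the fluoro of compound 3 would lower the number on compound 4 as well.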